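The compounds below may be only part of what the source reports. "The series", "measured", "known", "first", "only" and "open" are said of these compounds alone.

In a functional assay on 786-0 cells (Homo sapiens) for inhibition, read by sulforhodamine B assay, with a stated time of 48 h, tested at 0.01 uM (on this read-out higher numbers stand for a weaker effect at the one concentration tested and lower numbers for a stronger effect), the three measured compounds are:

compound 1, `O=C(Nc1cccc(-n2cc(-c3ccncc3)c(-c3cc(O)cc(Cl)c3)n2)c1)Nc1ccc(Cl)c(C(F)(F)F)c1`: 98%
compound 2, `O=C(Nc1cccc(-n2cc(-c3ccncc3)c(-c3cc(O)cc(Cl)c3)n2)c1)Nc1ccc(Cl)c(Cl)c1`: 92%
compound 3, `COc1cc(Cl)cc(-c2nn(-c3cccc(NC(=O)Nc4ccc(Cl)c(C(F)(F)F)c4)c3)cc2-c2ccncc2)c1`: 96%

Compound 3 stands second highest of these three numbers. Its nearest neighbour is compound 1 and its furthest is compound 2, and both separations lie within the scatter, so on present evidence the three compounds cannot be told apart in this assay; all sit at the high end of the read-out at the one concentration tested.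

Compound 4 is `COc1cc(Cl)cc(-c2nn(-c3cccc(NC(=O)Nc4ccc(Cl)c(Cl)c4)c3)cc2-c2ccncc2)c1`, not yet measured. It differs from compound 3 in one place: chloro in place of trifluoromethyl on an aromatic carbon.

Among the compounds with values here, one measured step bears directly on this change: the same exchange made on the pair that carries hydrogen rather than methyl on the aromatic oxygen gave a number 6 percentage points lower from compound 1 to compound 2 (within the scatter). Within the data shown here, the only other step in the set, the methyl for hydrogen on that oxygen, gave a number 2 percentage points lower from compound 1 to compound 3 (within the scatter). Neither moved the read-out beyond the scatter. The expectation for compound 4 in this assay is therefore a step of a number 4 percentage points lower from compound 3 to compound 4 (within the scatter), with no direction claimed beyond the scatter. Compound 4 is thus estimated at 92%, with a range from 83% to 100%.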

Compound 4, a percentage reported as activity, at one concentration (the size of the read-out at that concentration, not a potency): 100%
Compound 4: middle estimate off by 8 percentage points, on the low side; the measured number falls inside the stated range.
By their numbers in this assay, from the lowest: compounds 2, 3, 1 and 4 (each within the scatter of the next).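

With the methyl ether on the aromatic oxygen, chloro in place of trifluoromethyl in this assay gives a number 4 percentage points higher from compound 3 to compound 4 (within the scatter), so this exchange on the aromatic carbon now has a reading on two cores, and the two readings cannot be told apart: the same change on two cores in this assay, a number 6 percentage points lower (within the scatter) from compound 1 to compound 2 and a number 4 percentage points higher (within the scatter) from compound 3 to compound 4, 10 percentage points apart, within the scatter of two such steps

Read on the 3,4-dichlorophenyl side, methyl in place of hydrogen on the aromatic oxygen gives a number 8 percentage points higher from compound 2 to compound 4 (within the scatter), so that change also has a second reading, again not separable from the first: the same change on two cores in this assay, a number 2 percentage points lower (within the scatter) from compound 1 to compound 3 and a number 8 percentage points higher (within the scatter) from compound 2 to compound 4, 10 percentage points apart, within the scatter of two such steps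

Neither change has moved the read-out beyond the scatter on either core, so no direction can be assigned to either one, and the four compounds remain unseparated at the one concentration tested.

On these data alone, what an amine or a carboxylic acid would do in place of the chloro group at this aromatic carbon, or a longer chain on the aromatic oxygen, stays open in this assay. As far as these compounds go, how the four compounds compare at any other concentration also stays open, since a single concentration gives no potency.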